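The compounds below may be only part of what the source reports. "The series", "measured", "known", "first", "only" and "open" are said of these compounds alone.

Compound 1 `CN(C)CCCNc1nc2cc([N+](=O)[O-])ccc2nc1NCc1ccc(C(F)(F)F)cc1` gives 5.66 ug/mL
Compound 2 `COc1ccccc1CNc1nc2ccc([N+](=O)[O-])cc2nc1NCCCN(C)C` gives 36.1 ug/mL

In an ADME assay on HEK293 cells (Homo sapiens) for cytotoxicity, read by MTT assay, with a stated time of 24 h (on this read-out higher numbers stand for weaker inhibition and lower numbers for stronger inhibition), compound 2 holds the higher of the two numbers. Going by the values given here, the only measured step (a 6.4-fold higher number from compound 1 to compound 2 (0.80 log units; beyond the scatter)) is modest but beyond the scatter, and it puts 2-methoxyphenyl in place of 4-(trifluoromethyl)phenyl. The next change (3-bromophenyl in place of 2-methoxyphenyl on a saturated chain carbon bound to a nitrogen on an aromatic ring) puts 3-bromophenyl in place of 2-methoxyphenyl on a saturated chain carbon bound to a nitrogen on an aromatic ring, and it gives compound 3 (`CN(C)CCCNc1nc2cc([N+](=O)[O-])ccc2nc1NCc1cccc(Br)c1`). Among the compounds with values here, no measurement yet shows what 3-bromophenyl does here, so that single step is a partial guide only. Removing 2-methoxyphenyl is expected to lower the number in this assay, by somewhat less than the reverse of that step (a 3.3-fold lower number from compound 2 to compound 3 (0.52 log units; beyond the scatter)) as an expected size. For compound 3 the estimated value is 11 ug/mL and the expected range runs from 3.5 ug/mL to 32 ug/mL in this read-out.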

Compound 3, half-maximal inhibitory concentration: 3.66 ug/mL
Compound 3: the middle estimate sits 3.0-fold (0.48 log units) above what was measured; low and high end bracket the measured number.
By their numbers in this assay, from the lowest: compounds 3 and 1 (each within the scatter of the next); then compound 2.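

In this assay, 3-bromophenyl in place of 2-methoxyphenyl on this saturated chain carbon gives a 9.9-fold lower number from compound 2 to compound 3 (0.99 log units; beyond the scatter), so a second group now shows a step of this kind away from 2-methoxyphenyl. The other new comparison, a 1.5-fold lower number from compound 1 to compound 3 (0.19 log units; within the scatter), does not separate 3-bromophenyl from 4-(trifluoromethyl)phenyl, which leaves compound 2 alone at the high end of the three. Nothing available explains why 2-methoxyphenyl stands apart from the other two groups.

The compounds shown leave open whether the gap follows the methoxy group itself or the place it holds on the ring, which 3-methoxyphenyl or 4-methoxyphenyl would address. They also leave open how an unsubstituted phenyl or 2-bromophenyl would read here.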